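The compounds below may be only part of what the source reports. "The series", "measured", "known", "first", "only" and "open" are said of these compounds alone.

Compound 1 `COc1ccc(C2=C(c3cc(OC)c(OC)c(OC)c3)C(=O)C(OC(C)=O)C2)cc1OC(C)C`: > 100 ug/mL
Compound 2 `COc1ccc(C2=C(c3cc(OC)c(OC)c(OC)c3)C(=O)CC2C)cc1C(=O)O`: > 100 ug/mL
Compound 3 `COc1ccc(OC)c(C2=C(c3cc(OC)c(OC)c(OC)c3)C(=O)CC2O[SiH2]C(C)(C)C)c1`: 10 ug/mL

These three compounds were tested in an ADME assay on KB cells (Homo sapiens) for cytotoxicity, read by MTT assay, with a stated time of 72 h; a lower number here means a stronger inhibitor, a higher number a weaker inhibitor. Compound 1 gives > 100 ug/mL, which is a limit and not a number. Compound 2 also gives a limit, > 100 ug/mL. Compound 1 therefore stands at the limit of > 100 ug/mL in this assay, at which 2 of the 3 values shown sit. Compound 3 gives a true number, 10 ug/mL.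

Compound 4 `COc1ccc(C2=C(c3cc(OC)c(OC)c(OC)c3)C(=O)C(OC(C)=O)C2)cc1F` keeps the core of compound 1 with one change, fluoro in place of isopropoxy on an aromatic carbon. Among the measured compounds shown here, no measured pair isolates this change, so any expectation is uncertain. For the measured compounds named here, a move towards stronger inhibition, beyond the usual scatter, is expected, with compound 3 at 10 ug/mL as the only guide to a measurable value. The expected step is an at least 5.0-fold lower number from compound 1 to compound 4 (0.69 log units; beyond the scatter). The estimate for compound 4 is 20 ug/mL, with an expected range from 2 ug/mL to 100 ug/mL.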

Compound 4, half-maximal inhibitory concentration: 33 ug/mL
Estimate against measurement, compound 4: 1.7-fold (0.22 log units) below, and the stated range covers the measured number.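

Replacing isopropoxy with fluoro on this aromatic carbon, ortho to a methoxy group, gives an at least 3.0-fold lower number from compound 1 to compound 4 (0.48 log units; beyond the scatter) in this assay. Among the compounds shown here, this is the first sign that the group at this position affects the read-out on the acetoxy-bearing core of compound 1. The true size of the step stays unknown because compound 1 has only a limit: the limit of > 100 ug/mL in this assay, at which 2 of the 4 values shown sit.

The compounds shown do not tell whether the loss of isopropoxy or the arrival of fluoro matters more. Either a chloro group or an amine at this position could help separate the two.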